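This account rests on a few compounds, and the source may have more. Where it says the series, first, only, none or still open, it means among the compounds named here.

Of the compounds shown here, three have been measured in a functional assay on the whole organism (Tail, strain ICR) with Mus musculus as the target, in the tail flick test, with a stated time of 120 min, at a dose of 25 umol/kg by the oral route; a higher number here means a stronger effect of the compound at the dose given, a lower number a weaker effect. Compound 1, `O=C(CN(c1ncnc2c1ncn2C1CCCCO1)C1CC1)NCC(=O)OCc1ccccc1`, gives 17.2% in this assay. Compound 2, `NC(=O)C[C@H](NC(=O)CN(c1ncnc2c1ncn2C1CCCCO1)C1CC1)C(=O)OCc1ccccc1`, gives 29.2% in this assay. Compound 3, `NC(=O)CC[C@H](NC(=O)CN(c1nc(Cl)nc2[nH]cnc12)C1CC1)C(=O)O`, gives 17.8% in this assay; its value and that of compound 1 lie within the usual scatter of each other, while the value of compound 2 lies above both. Compound 3 has a different core from compound 2, and the difference between the two cores is not broken down here.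

Compound 4, `C[C@H](NC(=O)CN(c1nc(Cl)nc2[nH]cnc12)C1CC1)C(=O)O`, has not yet been measured in this assay. It differs from compound 3 by hydrogen in place of carbamoylmethyl on a saturated chain carbon, two bonds along the chain from an amide-type nitrogen and a carbonyl carbon. The same kind of change, (hydrogen in place of carbamoylmethyl on a saturated chain carbon bound to an amide-type nitrogen and a carbonyl carbon), has been measured once: a number 12 percentage points lower from compound 2 to compound 1 (beyond the scatter). The two places are not the same word for word: in the earlier change the carbon is bound to an amide-type nitrogen and a carbonyl carbon, whereas in compound 3 it lies two bonds along the chain from them. Because the earlier step was a number 12 percentage points lower from compound 2 to compound 1 (beyond the scatter), a step in the same direction is expected from compound 3 to compound 4, a number 8.8 percentage points lower from compound 3 to compound 4 (within the scatter). Compound 4 is therefore estimated to give 9% in this assay, between 0% and 20%.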

Compound 4, a percentage reported as activity, at one dose (the size of the read-out at that dose, not a potency): 28.4%
For compound 4 the middle estimate is 19.4 percentage points below the measured one, and the stated range ends below it.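

In this assay, putting hydrogen in place of carbamoylmethyl on the core of compound 3 gives a number 10.6 percentage points higher from compound 3 to compound 4 (beyond the scatter). Set beside the earlier step on the core of compound 1, the same kind of change moves the read-out in the opposite direction, so its effect in this series cannot simply be carried from one core to another: the same change on two cores in this assay, a number 12 percentage points lower (beyond the scatter) from compound 2 to compound 1 and a number 10.6 percentage points higher (beyond the scatter) from compound 3 to compound 4, 22.6 percentage points apart, beyond the scatter of two such steps This does not show why the two steps part ways, as each direction rests on a single pair of compounds, the two pairs differ in their cores and in what else they carry, and the carbamoylmethyl does not sit at quite the same place in the two pairs.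

The compounds shown leave open what the read-out would do with an amine or a hydroxyl group on that chain in place of carbamoylmethyl. They also leave open whether a third core would follow compound 2 and compound 1 or compound 3 and compound 4.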